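A second methoxy group on compound 1

The compounds below may be only part of what the source reports. "The series", "measured", "known", "first", "only" and "open" are said of these compounds alone.

Compound 1 `COc1ccc(SCc2ccc(C(=O)Nc3ccccc3N)cc2)cc1`: 81.8%
Compound 2 `Nc1ccccc1NC(=O)c1ccc(CSc2cccc(F)c2)cc1`: 76.3%

Both values come from a functional assay on A-375 cells (Homo sapiens) for inhibition, read by CCK-8 assay, with a stated time of 72 h, tested at 8 uM; on this read-out higher numbers stand for more inhibition of growth at the one concentration tested and lower numbers for less inhibition of growth. Compound 1 stands at 81.8% and has a single neighbour for comparison. That comparison swaps the group on the sulfur, 3-fluorophenyl in place of 4-methoxyphenyl, and gives a number 5.5 percentage points lower from compound 1 to compound 2 (within the scatter). The two compounds therefore cannot be ranked on these numbers.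

Compound 3 `COc1ccc(SCc2ccc(C(=O)Nc3ccccc3N)cc2)cc1OC` keeps the core of compound 1 and differs in one place: methoxy in place of hydrogen on an aromatic carbon. This is methoxy in place of hydrogen on an aromatic carbon, ortho to a methoxy group and meta to a large group. Among the measured compounds shown here, no measured step makes this exact change, so the evidence is indirect. For the measured compounds named here, the only guide is the step to compound 2, where replacing the group on the sulfur still gave only a number 5.5 percentage points lower from compound 1 to compound 2 (within the scatter). The addition of one methoxy group is therefore not expected to produce a step beyond the scatter in this assay, and neither direction is favoured. The expected change is a number 3.8 percentage points lower from compound 1 to compound 3 (within the scatter). The estimated value for compound 3 is 78%, with an expected range from 62% to 90%.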

Compound 3, percent growth inhibition at one concentration: 84.6%
The estimate for compound 3 lay 6.6 percentage points below the measured number, and the stated range covers the measured number.
By their numbers in this assay, from the lowest: compounds 2, 1 and 3 (each within the scatter of the next).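

In this assay, methoxy in place of hydrogen on an aromatic carbon, ortho to a methoxy group and meta to a large group, gives a number 2.8 percentage points higher from compound 1 to compound 3 (within the scatter). Among the compounds shown here, the earlier comparison replaced the whole group on the sulfur, whereas this one keeps that group and adds a single methoxy to it, so it is the first reading of this position on its own, and the added methoxy leaves the number within the scatter of the one without it. Nothing among the data shown accounts for this result, and no measurement speaks to what the added group does at this position.

The compounds shown leave open whether a different group at this position, such as an amine, a carboxylic acid or a longer chain like ethoxy, would give a step beyond the scatter. They also leave open whether compound 1 and compound 3 would stay within the scatter of each other at concentrations other than the one tested here.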